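A few compounds are considered here, and "the series" means these few. Any claim that something is new, unique, unknown or untested is made for them only; others in the source may bear on it.

- compound 1 `COCc1cc(CN2CCCC2)c(O)c2ncccc12`: 3550 nM
- compound 2 `COCc1cc(CN2CCCCC2)c(O)c2ncccc12`: 7590 nM

In a functional assay on MES-SA/Dx5 cells (Homo sapiens) for inhibition, with a stated time of 72 h, in the presence of a further agent that is not named here (on this read-out higher numbers stand for weaker inhibition and lower numbers for stronger inhibition), compound 2 holds the higher of the two numbers at 7590 nM, with compound 1 its nearest neighbour. Compound 3 `COCc1cc(CN2CCC(C)CC2)c(O)c2ncccc12` follows from compound 2 by methyl in place of hydrogen on a saturated ring carbon. Going by the values given here, the only measured step touching this amine ring is a 2.1-fold higher number from compound 1 to compound 2 (0.33 log units; beyond the scatter), a modest one from a different change, so it fixes no direction here. No shift beyond the scatter is expected in this assay. The expected step is a 1.1-fold lower number from compound 2 to compound 3 (0.04 log units; within the scatter). For compound 3 the estimate is 7000 nM, with an expected range of 3000 nM to 15000 nM.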

Compound 3, half-maximal inhibitory concentration: 4680 nM
Beside the measured number, compound 3's estimate is 1.5-fold (0.17 log units) above it; low and high end bracket the measured number.
By their numbers in this assay, from the lowest: compounds 1, 3 and 2 (each within the scatter of the next, the first and the last beyond it).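

In this assay, methyl on a saturated ring carbon, three ring bonds from the ring nitrogen, brings no shift beyond the scatter (a 1.6-fold lower number from compound 2 to compound 3 (0.21 log units; within the scatter)). The 4-methylpiperidin-1-yl group of compound 3 also stays within the scatter of the pyrrolidin-1-yl group of compound 1 (a 1.3-fold higher number from compound 1 to compound 3 (0.12 log units; within the scatter)), whereas the step from compound 1 to compound 2 lies beyond it. No measurement shown accounts for these numbers.

As far as these compounds go, whether an ethyl or hydroxyl group on this ring carbon would keep the number in the same range remains open. The same holds for morpholine or piperazine in place of the piperidine.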